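The source may report more compounds than this note shows. Statements on the series, on what has been measured and on what is new or still open speak of the compounds shown alone.

Of the compounds shown here, three of the shared core family have been measured. Compound 1 `Cc1nnc(SCc2ccccc2)n1N1C(=O)c2ccccc2C1=O` was tested in a functional assay on PC-3M cells (Homo sapiens) for cytotoxicity, read by MTT assay, with a stated time of 48 h (a higher number here means a weaker inhibitor, a lower number a stronger inhibitor), and the value of compound 1 is > 200000 nM, a limit of the assay rather than a number. Compound 2 `Cc1nnc(SCc2ccccc2Cl)n1N1C(=O)c2ccccc2C1=O` carries chloro in place of hydrogen on an aromatic carbon relative to compound 1. In this assay compound 2 gives > 200000 nM, again a limit. The step that the two limits leave unreadable from compound 1 to compound 2 therefore cannot be read. Compound 3 `CCc1nnc(SCC(=O)c2ccccc2)n1N1C(=O)c2ccccc2C1=O` rests on a different core, and how the cores of compound 1 and compound 3 differ is not broken down here. In this assay compound 3 gives > 200000 nM, also a limit. All three measured values sit at the limit of > 200000 nM in this assay, at which 3 of the 3 values shown sit. Compound 4 `CCc1nnc(SCC(=O)c2ccc(Cl)cc2)n1N1C(=O)c2ccccc2C1=O` has not yet been measured, and relative to compound 3 it carries chloro in place of hydrogen on an aromatic carbon. This is the same kind of change as that from compound 1 to compound 2, but the place differs: ortho to a large group in compound 2, para to a large group in compound 4. Because compound 1 and compound 2 both sit at the limit of > 200000 nM in this assay, at which 3 of the 3 values shown sit, the earlier step gives no size to lean on. The step is nonetheless expected to be a number no higher from compound 3 to compound 4 (the limit leaves the size open). For compound 4 in this assay the expected value is 200000 nM, most likely again reported only as a limit.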

Compound 4, half-maximal inhibitory concentration: > 200000 nM
Compound 4 ended at the assay's limit; the forecaster's own chance of this, stated with the estimate: 85%; the middle value lies on the limit itself.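

In this assay no size can be given for the step between compound 3 and compound 4, since both values are limits of the assay and not numbers: the limit of > 200000 nM in this assay, at which 4 of the 4 values shown sit.

The compounds shown leave open whether chloro in place of hydrogen on an aromatic carbon changes cytotoxicity at all, and what real number any of these four compounds would give.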